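Replacing the enol ether oxygen with an anilino nitrogen

The source may hold more compounds than are shown below. What is called first, only, known or untested is meant among the compounds shown, and "the series" means these compounds.

The measured compounds:
compound 1, `O=C(C1=C(O)C(=O)N(CCCn2ccnc2)C1c1ccc(Br)cc1)c1ccccc1`, gives 20000 nM in a functional assay on NCI-H1299 cells (Homo sapiens) for antiproliferative activity, read by MTT assay, with a stated time of 72 h; a higher number here means a weaker inhibitor, a lower number a stronger inhibitor
compound 2, `CCCCOC1=C(C(=O)c2ccccc2)C(c2ccc(Br)cc2)N(CCCn2ccnc2)C1=O`, gives 17100 nM in this assay
compound 3, `O=C(C1=C(OC2CCCCC2)C(=O)N(CCCn2ccnc2)C1c1ccc(Br)cc1)c1ccccc1`, gives 19900 nM in this assay

Compound 3 holds the second highest of the three numbers, and every pair among them lies within the usual scatter: a 1.0-fold lower number from compound 1 to compound 3 (0.00 log units; within the scatter), a 1.2-fold lower number from compound 1 to compound 2 (0.07 log units; within the scatter) and a 1.2-fold higher number from compound 2 to compound 3 (0.07 log units; within the scatter). So far, then, nothing attached to that oxygen has moved the read-out.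

Compound 4, `O=C(C1=C(Nc2ccccc2)C(=O)N(CCCn2ccnc2)C1c1ccc(Br)cc1)c1ccccc1`, differs from compound 3 in one place: anilino in place of cyclohexyloxy on a double-bonded ring carbon. The steps from compound 1 to compound 3 and from compound 2 to compound 3 bear on this only in part, since each of them changed what sits on the oxygen while the oxygen stayed; here the oxygen itself gives way to a nitrogen that carries a hydrogen. Going by the values given here, no measured step covers that exchange, so the expectation rests on the flat picture seen so far. With all three measured steps within the scatter, compound 4 is expected to show a 1.2-fold lower number from compound 3 to compound 4 (0.09 log units; within the scatter), with no direction favoured. The estimate for compound 4 in this assay is 16000 nM, with a range from 5000 nM to 45000 nM.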

Compound 4, half-maximal inhibitory concentration: 21200 nM
Beside the measured number, compound 4's estimate is 1.3-fold (0.12 log units) below it, within the range that was stated.
By their numbers in this assay, from the lowest: compounds 2, 3, 1 and 4 (each within the scatter of the next).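

Exchanging the oxygen itself for a nitrogen carrying a hydrogen goes further than the earlier changes, which altered only what sat on that oxygen, yet in this assay anilino in place of cyclohexyloxy gives a 1.1-fold higher number from compound 3 to compound 4 (0.03 log units; within the scatter) at this double-bonded ring carbon. The other two comparisons agree, since anilino in place of butoxy gives a 1.2-fold higher number from compound 2 to compound 4 (0.09 log units; within the scatter) and anilino in place of hydroxy gives a 1.1-fold higher number from compound 1 to compound 4 (0.03 log units; within the scatter) in the same read-out, so across these four compounds neither the atom attached to the ring carbon nor the swap of a non-aromatic six-membered ring for an aromatic one separates the numbers. No supporting measurement is available to explain this flat result.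

The compounds shown leave open whether any group at this carbon can move the read-out beyond the scatter, for example a primary amine, a carboxylic acid or a longer alkyl chain. They also leave open what changes elsewhere would do, as the benzoyl, 4-bromophenyl and 3-(1H-imidazol-1-yl)propyl groups are the same in all four compounds.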